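Replacing butyl with hex-1-yn-1-yl in compound 2

This account rests on a few compounds, and the source may have more. Where it says the series, first, only, none or still open, it means among the compounds named here.

In a functional assay on HEL cells (Homo sapiens) (on this read-out higher numbers stand for lower toxicity in this test and lower numbers for higher toxicity in this test), compound 1 `CCCCCCCCCCc1cc2cn(COCCO)c(O)nc-2n1` gives 32000 nM and compound 3 `CCCCCCCCc1cc2cn(COCCO)c(O)nc-2n1` gives 65000 nM. Compound 2 `CCCCc1cc2cn(COCCO)c(=O)nc2o1` reads > 200000 nM, which is a limit of the assay and not a number. Compound 4 `CCCCC#Cc1cc2cn(COCCO)c(=O)nc2o1` carries hex-1-yn-1-yl in place of butyl on an aromatic carbon. For the measured compounds named here, one measured step bears on this, on a different core, with hydrogen in place of ethyl on a saturated chain carbon: a 2.0-fold higher number from compound 1 to compound 3 (0.31 log units; beyond the scatter). Read in reverse, this modest step leads one to expect a similarly modest fall in this assay for the longer group, starting from a limit. The estimated step is an at least 1.5-fold lower number from compound 2 to compound 4 (0.18 log units; that floor lies within the scatter). Compound 4 is expected at 130000 nM, within an estimated range of 50000 nM to 250000 nM.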

Compound 4, half-maximal cytotoxic concentration: > 50000 nM
Compound 4 was reported as a limit (the forecaster's own chance of this, stated with the estimate: 45%); the middle value does not contradict the limit.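

In this assay compound 2 reads > 200000 nM, which is a limit. For the compounds shown here, compound 4 reads > 50000 nM, also a limit, so no step between compound 2 and compound 4 can be read. On these data alone, how hex-1-yn-1-yl in place of butyl changes this read-out stays open.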